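The source may report more compounds than this note shows. Statements on the series, on what has been measured and on what is new or still open speak of the compounds shown alone.

Three compounds have so far been measured in a functional assay on DLD-1 cells (Homo sapiens) for inhibition, read by MTT assay, with a stated time of 72 h; a higher number here means a weaker inhibitor, a lower number a stronger inhibitor:

compound 1 `CNCc1c(OC)cc(Oc2cccc(Nc3ccccc3)c2)cc1OC` gives 11900 nM;
compound 2 `COc1cc(Oc2cccc(Nc3ccccc3)c2)cc(OC)c1CNCc1ccc(C)cc1` gives 6080 nM;
compound 3 `COc1cc(Oc2cccc(Nc3ccccc3)c2)cc(OC)c1CNC1CC1` gives > 20000 nM, which is a limit of the assay and not a number.

For the measured compounds named here, compound 3 thus stands apart from the other two in that its result is only a limit, the one compound sitting at the limit of > 20000 nM in this assay, at which 1 of the 3 values shown sits. The step of an at least 3.2-fold higher number from compound 2 to compound 3 (0.51 log units; beyond the scatter) is beyond the scatter, whereas the step of an at least 1.6-fold higher number from compound 1 to compound 3 (0.22 log units; that floor lies within the scatter) has a floor that still lies inside it. Compound 4 `COc1cc(Oc2cccc(Nc3ccccc3)c2)cc(OC)c1CNCc1ccc(O)cc1` is the next analogue and differs from compound 3 by 4-hydroxybenzyl in place of cyclopropyl on an amine nitrogen. Going by the values given here, two measured steps bear on this change, both at the same amine nitrogen: a 2.0-fold lower number from compound 1 to compound 2 (0.29 log units; within the scatter) stays within the scatter, and an at least 3.2-fold higher number from compound 2 to compound 3 (0.51 log units; beyond the scatter) shows that exchanging the 4-methylbenzyl group for cyclopropyl pushed the number past the limit. Compound 4 brings a benzyl group back, now carrying a hydroxyl, so the step is expected to run the other way, toward a lower number. Compound 4 is therefore expected to show an at least 2.5-fold lower number from compound 3 to compound 4 (0.39 log units; beyond the scatter) in this assay. The estimated value for compound 4 in this assay is 8000 nM, with a range from 3000 nM to 20000 nM.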

Compound 4, half-maximal inhibitory concentration: 2690 nM
Compound 4: middle estimate off by 3.0-fold (0.47 log units), on the high side; the measured number lies below the stated range.
By their numbers in this assay, from the lowest: compound 4; then compounds 2 and 1 (each within the scatter of the next). At a limit, above all of these: compound 3.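

At this amine nitrogen, 4-hydroxybenzyl in place of the methyl of compound 1 gives a 4.4-fold lower number from compound 1 to compound 4 (0.65 log units; beyond the scatter) in this assay and so clears the scatter, which 4-methylbenzyl did not do. The group on the aromatic ring of the benzyl substituent also counts, since hydroxy in place of methyl on an aromatic carbon gives a 2.3-fold lower number from compound 2 to compound 4 (0.35 log units; beyond the scatter) and shows that the presence of a benzyl group alone does not set the number. Against cyclopropyl the change reads as an at least 7.4-fold lower number from compound 3 to compound 4 (0.87 log units; beyond the scatter) and is only a floor, for the result of compound 3 is a limit of the assay and not a number: the limit of > 20000 nM in this assay, at which 1 of the 4 values shown sits.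

The compounds shown leave open whether the oxygen of the hydroxy group is what counts, which a methoxy group or an amine in its place on the benzyl group would test. They also leave open how an unsubstituted benzyl group, or a longer chain between the amine nitrogen and the aromatic ring, would read in this assay on the same shared core.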